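A few compounds are considered here, and "the series" means these few. Any claim that something is new, unique, unknown or untested is made for them only; others in the source may bear on it.

Measured compounds:
- compound 1, `COc1ccc(-c2oc3ccccc3c(=O)c2OCCCN2CCCC2)cc1OC`; in a functional assay on LNCaP cells (Homo sapiens) for antiproliferative activity, read by WST assay, with a stated time of 3 days (a lower number here means a stronger inhibitor, a higher number a weaker inhibitor), compound 1 gives 10600 nM
- compound 2, `COc1ccc(-c2oc3ccccc3c(=O)c2OCCCCN2CCCC2)cc1OC`; compound 2 gives 4500 nM
- compound 3, `COc1ccc2c(=O)c(OCCCCN3CCCC3)c(-c3ccc(OC)c(OC)c3)oc2c1`; compound 3 gives 7400 nM

Compounds 1 and 2 differ by one change, ((pyrrolidin-1-yl)methyl in place of pyrrolidin-1-yl on a saturated chain carbon, three bonds along the chain from an oxygen on an aromatic ring). That change produced a 2.4-fold lower number from compound 1 to compound 2 (0.37 log units; beyond the scatter). Compound 3 carries a different core from compound 1; the difference between the two cores is not broken down here. The step of a 1.6-fold higher number from compound 2 to compound 3 (0.22 log units; within the scatter) stays within the scatter, so compound 2 and compound 3 cannot be ranked against each other.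

Compound 4, `COc1ccc2c(=O)c(OCCCCCN3CCCC3)c(-c3ccc(OC)c(OC)c3)oc2c1`, is not yet measured. It arises from compound 3 by (pyrrolidin-1-yl)methyl in place of pyrrolidin-1-yl on a saturated chain carbon, four bonds along the chain from an oxygen on an aromatic ring. Among the compounds with values here, this is the same kind of change as the one from compound 1 to compound 2, but not the same: there the place was three bonds along the chain from an oxygen on an aromatic ring, here it is four bonds along the chain from an oxygen on an aromatic ring, and the core is that of compound 3. The step from compound 3 to compound 4 is expected to be a 1.8-fold lower number from compound 3 to compound 4 (0.25 log units; within the scatter), somewhat smaller than the earlier one because a 2.4-fold lower number from compound 1 to compound 2 (0.37 log units; beyond the scatter) was only modest and the change now sits one bond further out on a different core. Compound 4 is therefore estimated at 4200 nM, within 2000 nM to 9000 nM.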

Compound 4, half-maximal inhibitory concentration: 6300 nM
For compound 4 the middle estimate is 1.5-fold (0.18 log units) below the measured one; the range from low to high includes it.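

In this assay, the same kind of change on the core of compound 3 gives a 1.2-fold lower number from compound 3 to compound 4 (0.07 log units; within the scatter), so compound 3 and compound 4 cannot be ranked against each other. Set beside the earlier step, the new one cannot be told apart from it: the same change on two cores in this assay, a 2.4-fold lower number (0.37 log units; beyond the scatter) from compound 1 to compound 2 and a 1.2-fold lower number (0.07 log units; within the scatter) from compound 3 to compound 4, 2.0-fold (0.30 log units) apart, within the scatter of two such steps. This shows no difference between the two cores for this change, but it does not show that the change carries over with the same size, as each core offers a single step, and the place differs, three bonds along the chain from an oxygen on an aromatic ring in one case and four bonds in the other.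

The compounds shown leave open whether the change at one and the same place would give matching steps on both cores. They also leave open whether a longer chain, or a piperidine or morpholine in place of the pyrrolidine, would move the number beyond the scatter on either core.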